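Moving the trifluoromethyl group on the benzyl arm

A few compounds are considered here, and "the series" means these few. Any claim that something is new, unique, unknown or untested is made for them only; others in the source may bear on it.

Measured in a functional assay on A549 cells (Homo sapiens) for cytotoxicity, read by MTT assay; a lower number here means a stronger inhibitor, a higher number a weaker inhibitor:
compound 1 `Oc1ccc(CN(Cc2ccccc2)Cc2ccc(O)c3ncccc23)c2cccnc12`: 544 nM
compound 2 `Oc1ccc(CN(Cc2ccccc2C(F)(F)F)Cc2ccc(O)c3ncccc23)c2cccnc12`: 46 nM

Compound 2 holds the lower of the two numbers in this assay, and the gap to the other compound is beyond the scatter. Next is compound 3 `Oc1ccc(CN(Cc2cccc(C(F)(F)F)c2)Cc2ccc(O)c3ncccc23)c2cccnc12`, with the change 3-(trifluoromethyl)phenyl in place of 2-(trifluoromethyl)phenyl on a saturated chain carbon bound to an amine nitrogen.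

Among the compounds with values here, one measured step bears on this: a 12-fold lower number from compound 1 to compound 2 (1.07 log units; beyond the scatter), a large step that came with trifluoromethyl in place of hydrogen on an aromatic carbon. Within the data shown here, no measured pair moves the group, so its dependence on location is unknown. Compound 3 keeps the group, so part of that large step is expected to survive. A small step toward a higher number is expected: a 2.2-fold higher number from compound 2 to compound 3 (0.34 log units; beyond the scatter). For compound 3 the estimated value is 100 nM, with an expected range of 25 nM to 400 nM.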

Compound 3, half-maximal inhibitory concentration: 38 nM
The estimate for compound 3 lay 2.6-fold (0.42 log units) above the measured number; low and high end bracket the measured number.
By their numbers in this assay, from the lowest: compounds 3 and 2 (each within the scatter of the next); then compound 1.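

In this assay the change from 2-(trifluoromethyl)phenyl to 3-(trifluoromethyl)phenyl gives a 1.2-fold lower number from compound 2 to compound 3 (0.08 log units; within the scatter), so these two placements of the group cannot be told apart on this arm. The large step over the plain benzyl arm is thus not confined to one placement: the second placement also gives a 14-fold lower number from compound 1 to compound 3 (1.16 log units; beyond the scatter), matching in direction the step already seen with the first. Nothing on hand explains why the move leaves the number within the scatter.

On these data alone, whether the large step needs trifluoromethyl itself stays open, and a chlorine, a methoxy group or a nitrile on the same arm would test that. Also open, as far as these compounds go, is whether a longer chain between the amine nitrogen and the aromatic ring would preserve numbers of this size.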